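Hydrazone carbamoyl series: aryl change on the five-membered ring

This account rests on a few compounds, and the source may have more. Where it says the series, first, only, none or still open, it means among the compounds named here.

Measured so far:
- compound 1 `C=C(C)[C@@H]1CC=C(C)/C(=N/NC(=O)Nc2nnc(-c3ccc(OC)cc3)o2)C1`: 300 mg/kg
- compound 2 `C=C(C)[C@@H]1CC=C(C)/C(=N/NC(=O)Nc2nnc(-c3ccc(F)cc3)o2)C1`: 300 mg/kg
- compound 3 `C=C(C)[C@@H]1CC=C(C)/C(=N/NC(=O)Nc2nnc(-c3ccc(C)cc3)o2)C1`: 300 mg/kg

All three share one core and differ only in the group on the aromatic carbon of the five-membered ring. In a functional assay on the whole organism (strain Swiss albino) with Mus musculus as the target, with a stated time of 4 h (on this read-out lower numbers stand for an effect already at smaller amounts and higher numbers for an effect only at larger amounts of compound), compound 1 gives 300 mg/kg. Compound 2 gives 300 mg/kg and compound 3 gives 300 mg/kg, so compound 1 stands level with both, its nearest neighbour being compound 2 and its furthest compound 3, each within the scatter. The steps of no change at the digits printed from compound 1 to compound 2 (within the scatter), no change at the digits printed from compound 1 to compound 3 (within the scatter) and no change at the digits printed from compound 2 to compound 3 (within the scatter) all show no movement in this assay.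

Compound 4 `C=C(C)[C@@H]1CC=C(C)/C(=N/NC(=O)Nc2nnc(-c3ccccc3O)o2)C1` is not yet measured. It differs from compound 1 as follows: 2-hydroxyphenyl in place of 4-methoxyphenyl on an aromatic carbon. The measured steps all exchange one group at this same position, and none of them moved the minimum effective dose. Among the compounds with values here, no measured step introduces a hydrogen-bond donor at this position, so that part of the change is uncharted; still, the steps of no change at the digits printed from compound 1 to compound 2 (within the scatter) and no change at the digits printed from compound 1 to compound 3 (within the scatter) point to a step of no size beyond the scatter.

Compound 4 is therefore expected to give 300 mg/kg, between 150 mg/kg and 600 mg/kg, which corresponds to an estimated step of no change at the digits printed from compound 1 to compound 4 (within the scatter).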

Compound 4, minimum effective dose: 300 mg/kg
The estimate for compound 4 equals the measured number at the digits printed; the range from low to high includes it.
By their numbers in this assay, from the lowest: compounds 1, 2, 3 and 4 (each within the scatter of the next).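

In this assay, 2-hydroxyphenyl on this aromatic carbon gives no change at the digits printed from compound 1 to compound 4 (within the scatter), together with no change at the digits printed from compound 2 to compound 4 (within the scatter) and no change at the digits printed from compound 3 to compound 4 (within the scatter). Here the exchange adds a hydrogen-bond donor and places the substituent differently on the phenyl ring, unlike the 4-methoxyphenyl, 4-fluorophenyl and 4-methylphenyl compounds, and neither difference separates compound 4 from them in this read-out. No measured information on the compounds accounts for this flat result.

With all four compounds level, the shown data do not reveal whether any group at this position can shift the minimum effective dose. On these data alone, whether an amine, a carboxylic acid or a longer alkyl chain in place of the phenyl group would do so remains open, as does the role of the shared core.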